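Removing the Methyl from the Methoxy Group of Compound 1

The compounds below may be only part of what the source reports. "The series", "measured", "known", "first", "only" and "open" are said of these compounds alone.

The measured compounds and their values in an assay for binding affinity to Corticotropin releasing factor receptor (Rattus norvegicus); a lower number here means a stronger inhibitor, a higher number a weaker inhibitor:
compound 1 `CCCC(C)n1c(CC)nc2c(-c3ccc(OC)nc3C(F)(F)F)ccnc21`: 0.6 nM
compound 2 `CCc1nc2c(-c3ccc(OC)nc3C(F)(F)F)ccnc2n1C(C)CC`: 0.7 nM
compound 3 `CCc1nc2c(-c3ccc(OC)nc3C(F)(F)F)ccnc2n1C(CC)CCOC`: 1.6 nM

Compound 1 holds the lowest of the three numbers. Compound 2 sits close to it, with a 1.2-fold higher number from compound 1 to compound 2 (0.07 log units; within the scatter), while compound 3 lies further off, with a 2.7-fold higher number from compound 1 to compound 3 (0.43 log units; beyond the scatter) and, seen from compound 2, a 2.3-fold higher number from compound 2 to compound 3 (0.36 log units; beyond the scatter).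

Compound 4 `CCCC(C)n1c(CC)nc2c(-c3ccc(O)nc3C(F)(F)F)ccnc21` differs from compound 1 only at the oxygen on an aromatic ring: hydrogen in place of methyl on an oxygen on an aromatic ring, the methoxy becoming a hydroxy. Within the data shown here, all three measured steps concern the chain on the aromatic nitrogen, and none touches this oxygen, so no measured step bears directly on the change. They show only that this series tolerates small changes at one position with modest shifts at most.

Compound 4 is therefore expected to remain a strong binder, with a modest weakening estimated as a 5.0-fold higher number from compound 1 to compound 4 (0.70 log units; beyond the scatter). The estimate for compound 4 in this assay is 3 nM, with a range from 0.7 nM to 15 nM.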

Compound 4, inhibition constant: 602 nM
Estimate against measurement, compound 4: 200-fold (2.30 log units) below; the whole stated range lies below it.
By their numbers in this assay, from the lowest: compounds 1 and 2 (each within the scatter of the next); then compound 3; then compound 4.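

In this assay the change from methoxy to hydroxy on an oxygen on an aromatic ring gives a 1000-fold higher number from compound 1 to compound 4 (3.00 log units; beyond the scatter) and so forms a large step, whereas the changes on the chain on the aromatic nitrogen among compound 1, compound 2 and compound 3 stayed modest or within the scatter. Among the compounds shown, this oxygen is thus far more sensitive than that chain, and the loss of a single methyl sets compound 4 apart from the other three. Nothing measured here explains why the number rises so far at this oxygen.

Going by these compounds, whether an ethoxy group on this oxygen, or an amine in its place, would keep the number near that of compound 1 stays open. Also open, on these data alone, is whether the same change would cost as much with the 1-(2-methoxyethyl)propyl chain of compound 3 on the aromatic nitrogen.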